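The source may hold more compounds than are shown below. What is called first, only, known or untested is meant among the compounds shown, and "the series" means these compounds.

Measured so far in a physicochemical assay for solubility, read by HPLC, in phosphate buffer, measured as kinetic solubility, at pH 7.4; a higher number here means a more soluble compound, a lower number a less soluble compound:
- compound 1 (`CCOC(=O)c1cc(-c2ccccc2Cl)n(-c2ccc(S(N)(=O)=O)cc2)c1C`) at 13700 nM
- compound 2 (`CCC(=O)c1cc(-c2ccc(S(N)(=O)=O)cc2)n(-c2ccc(Cl)cc2)n1`) at 41900 nM

Compound 2 stands highest of the two, and compound 1 lies lower by a gap beyond the scatter. Compound 3 (`NS(=O)(=O)c1ccc(-c2cc(C(=O)CC3CCCC3)nn2-c2ccc(Cl)cc2)cc1`) carries, against compound 2, the change cyclopentyl in place of methyl on a saturated chain carbon bound to a carbonyl carbon with cyclopentyl in place of methyl on a saturated chain carbon bound to a carbonyl carbon. Within the data shown here, no measured pair differs in one place, so the expectation rests on the structural change alone. A fall beyond the scatter is expected in this assay here, the estimated step being a 5.2-fold lower number from compound 2 to compound 3 (0.72 log units; beyond the scatter) in size. For compound 3 the estimated value is 8000 nM with an expected range of 1500 nM to 30000 nM for the measurement.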

Compound 3, solubility: 2600 nM
Estimate against measurement, compound 3: 3.1-fold (0.49 log units) above; measured number inside the range.
By their numbers in this assay, from the lowest: compound 3; then compound 1; then compound 2.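

Cyclopentyl in place of methyl on a saturated chain carbon bound to a carbonyl carbon gives the series its first single-place comparison, and in this assay it produces a 16-fold lower number from compound 2 to compound 3 (1.21 log units; beyond the scatter), a large step. The read-out at this position therefore responds strongly to this change. No evidence available here accounts for the fall.

As far as these compounds go, whether the ring itself matters, or only the added carbons, stays open, as a longer open chain of similar size would be needed to separate the two. From the compounds shown here alone, how an amine or a carboxylic acid at this place would compare with compound 2 also stays open.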